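The source may hold more compounds than are shown below. What is called first, only, known or untested is meant among the compounds shown, and "the series" means these compounds.

Working notes on the series.

Compound 3 `CC1=CC[C@H](C(C)(C)NC(=S)N/N=C/c2ccccc2Cl)CC1` carries a 2-chlorophenyl on the carbon double-bonded to nitrogen. Within the data shown here, in a functional assay on UACC-62 cells (Homo sapiens) for inhibition, read by sulforhodamine B assay, with a stated time of 48 h (a lower number here means a stronger inhibitor of growth, a higher number a weaker inhibitor of growth), compound 3 gives 19300 nM, the second highest of the three numbers measured so far. Its nearest neighbour is compound 2 `COc1ccc(/C=N/NC(=S)NC(C)(C)[C@H]2CC=C(C)CC2)cc1`, which in this assay gives 13300 nM; the step of a 1.5-fold higher number from compound 2 to compound 3 (0.16 log units; within the scatter). The furthest is compound 1 `CC1=CC[C@H](C(C)(C)NC(=S)N/N=C/c2ccccc2)CC1`, which in this assay gives 31600 nM; the step of a 1.6-fold lower number from compound 1 to compound 3 (0.21 log units; within the scatter). For comparison, a 2.4-fold lower number from compound 1 to compound 2 (0.38 log units; beyond the scatter).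

Compound 4 `CC1=CC[C@H](C(C)(C)NC(=S)N/N=C/c2cccc(Cl)c2)CC1` differs from compound 3 by 3-chlorophenyl in place of 2-chlorophenyl on a carbon with a double bond to nitrogen. Among the measured compounds shown here, the two steps that bear on this change, a 1.6-fold lower number from compound 1 to compound 3 (0.21 log units; within the scatter) and a 1.5-fold higher number from compound 2 to compound 3 (0.16 log units; within the scatter), both show that a 2-chlorophenyl in this position shifts the number little, and no measured compound yet carries a 3-chlorophenyl. Moving the chloro within the same ring is therefore expected to give a step of similar size, a 1.1-fold lower number from compound 3 to compound 4 (0.06 log units; within the scatter), with no clear direction beyond the scatter. For compound 4 the expected value in this assay is 17000 nM, with a range from 8000 nM to 36000 nM.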

Compound 4, concentration for 50% growth inhibition: 9000 nM
Beside the measured number, compound 4's estimate is 1.9-fold (0.28 log units) above it; measured number inside the range.
By their numbers in this assay, from the lowest: compounds 4, 2, 3 and 1 (each within the scatter of the next, the first and the last beyond it).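

In this assay, among these compounds, the place of the chloro on the ring now counts: with the same atoms joined differently, the change gives a 2.1-fold lower number from compound 3 to compound 4 (0.33 log units; beyond the scatter), which no earlier compound could show, as none carried a 3-chlorophenyl. Set against the plain phenyl, the 3-chlorophenyl gives a 3.5-fold lower number from compound 1 to compound 4 (0.55 log units; beyond the scatter), while against the 4-methoxyphenyl it gives a 1.5-fold lower number from compound 2 to compound 4 (0.17 log units; within the scatter), so compound 2 and compound 4 are not separated by this measurement. No data are at hand to say why the place of the chloro matters.

Open, going by these compounds, is whether an aromatic ring carrying an amine or a carboxylic acid, on the carbon with a double bond to nitrogen, would keep or lose this level of growth inhibition. Also open, on these data alone, is whether the step between the two chlorophenyl groups holds in any other cell line.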